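The source may report more compounds than this note shows. Statements on the series, on what has been measured and on what is new or still open speak of the compounds shown alone.

In a functional assay on MIA PaCa-2 cells (Homo sapiens) for antiproliferative activity, read by sulforhodamine B assay, with a stated time of 48 h (a higher number here means a weaker inhibitor, a lower number a stronger inhibitor), compound 2 `COc1ccc(C(=O)/C=C\Nc2ccc(-c3nc4cc(OC)c(OC)c(OC)c4s3)cc2C)cc1O` gives 15400 nM, compound 1 `COc1cc(OC)c2sc(-c3ccc(N/C=C\C(=O)c4ccc(OC)c(O)c4)c(C)c3)nc2c1` gives 22100 nM and compound 3 `COc1ccc(C(=O)/C=C\Nc2ccc(-c3nc4cc(OC)c(OC)c(OC)c4s3)cc2C)cc1[N+](=O)[O-]` gives 23400 nM, so compound 2 stands within the scatter of both. Compound 4 `COc1ccc(C(=O)/C=C\Nc2ccc(-c3nc4cc(OC)c(OC)c(OC)c4s3)cc2)cc1O` carries hydrogen in place of methyl on an aromatic carbon, ortho to a large group and meta to a large group: hydrogen in place of methyl on an aromatic carbon. Neither measured step involves this place. The measured steps, a 1.4-fold lower number from compound 1 to compound 2 (0.16 log units; within the scatter) and a 1.5-fold higher number from compound 2 to compound 3 (0.18 log units; within the scatter), are small and give only indirect guidance. No change beyond the scatter is therefore expected in this assay, and no direction is favoured. The expected step is a 1.0-fold lower number from compound 2 to compound 4 (0.01 log units; within the scatter). For compound 4 the estimate is 15000 nM, with an expected range of 6000 nM to 38000 nM.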

Compound 4, half-maximal inhibitory concentration: 32800 nM
Compound 4: middle estimate off by 2.2-fold (0.34 log units), on the low side, and the stated range covers the measured number.
By their numbers in this assay, from the lowest: compounds 2, 1, 3 and 4 (each within the scatter of the next, the first and the last beyond it).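

In this assay, hydrogen in place of methyl on this aromatic carbon, ortho to a large group and meta to a large group, gives a 2.1-fold higher number from compound 2 to compound 4 (0.33 log units; beyond the scatter). Going by these compounds alone, this is the first single change to pass beyond the scatter, as the two earlier steps, made elsewhere in the structure, both stayed within it. No measurement shown accounts for this step.

The step rests on one pair of compounds. From the compounds shown here alone, whether ethyl or chlorine at this position would match methyl remains open, as does whether the methyl matters equally with the nitro group of compound 3.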